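The source may report more compounds than this note shows. Statements on the series, on what has been measured and on what is new or still open speak of the compounds shown alone.

Two compounds of the series have numbers in an assay on isolated protein with Bile acid receptor (Homo sapiens) as the target; on this read-out higher numbers stand for an effect only at larger amounts of compound and lower numbers for an effect already at smaller amounts. Compound 1 `COC(=O)/C=C/c1cccc(N(Cc2ccc(/C=C/c3cccc(C(F)(F)F)c3)cc2)C(=O)NC(C)C)c1` gives 932 nM in this assay. Compound 2 `COC(=O)/C=C/c1cccc(N(Cc2ccc(/C=C/c3c(F)cccc3F)cc2)C(=O)C(C)C)c1` gives 108 nM in this assay, the lower of the two numbers and beyond the scatter from compound 1; the two differ in more than one place, so the gap between them is not assigned to any single change. Compound 3 `COC(=O)/C=C/c1cccc(N(Cc2ccc(-c3cc(Cl)ccc3OC)cc2)C(=O)C(C)C)c1` follows from compound 2 by one change (5-chloro-2-methoxyphenyl in place of 2-(2,6-difluorophenyl)ethenyl on an aromatic carbon). Going by the values given here, no measured pair shows this change, so the step from compound 2 to compound 3 is expected to be a moderate move toward a higher number, a 2.8-fold higher number from compound 2 to compound 3 (0.44 log units; beyond the scatter). Compound 3 is expected to give about 300 nM in this assay, with a range from 80 nM to 1200 nM.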

Compound 3, half-maximal effective concentration: 226 nM
For compound 3 the middle estimate is 1.3-fold (0.12 log units) above the measured one; measured number inside the range.
By their numbers in this assay, from the lowest: compound 2; then compound 3; then compound 1.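

In this assay, 5-chloro-2-methoxyphenyl in place of 2-(2,6-difluorophenyl)ethenyl gives a 2.1-fold higher number from compound 2 to compound 3 (0.32 log units; beyond the scatter), a modest step. This position therefore accepts the loss of the double bond outside aromatic rings and both fluorines, with the number moving only this far. Nothing available accounts for the size or direction of this step.

Going by these compounds, the double bond and the ring substituents change together here, so which of them carries the step stays open. On these data alone, how an amine or a carboxylic acid at this position would read also stays open.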